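The source may hold more compounds than are shown below. What is called first, only, known or untested is meant among the compounds shown, and "the series" means these compounds.

Compound 1 `CC(C)=CC(O)C1=CC(=O)c2ccccc2C1=O`: 5200 nM
Compound 2 `O=C(C1=CC(=O)c2ccccc2C1=O)c1ccc(Cl)cc1`: 72900 nM

Both values come from a functional assay on WHCO1 cells (Homo sapiens) for cytotoxicity, read by MTT assay, with a stated time of 24 h; a lower number here means a stronger inhibitor, a higher number a weaker inhibitor. Among the measured compounds shown here, of the two compounds measured so far, compound 1 has the lower number and so is the stronger inhibitor, and its gap to compound 2 lies beyond the usual scatter.

Compound 3 `O=C1C=C(C(O)c2cccc(F)c2)C(=O)c2ccccc21` keeps the core of compound 1 and changes one group: 3-fluorophenyl in place of 2-methylprop-1-en-1-yl on a saturated chain carbon bound to a double-bonded ring carbon and an oxygen on a saturated carbon.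

For the measured compounds named here, no measured pair shows this change, so any forecast is loose. The starting point is compound 1 at 5200 nM, and compound 2 at 72900 nM shows that a much higher number is possible, so the range is left wider on the upper side. In this assay, the expected result is a 1.3-fold higher number from compound 1 to compound 3 (0.13 log units; within the scatter), a modest move towards weaker inhibition that may not clear the scatter. The estimated value for compound 3 is 7000 nM, with an expected range of 2500 nM to 20000 nM.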

Compound 3, half-maximal inhibitory concentration: 5500 nM
Compound 3: middle estimate off by 1.3-fold (0.10 log units), on the high side; measured number inside the range.
By their numbers in this assay, from the lowest: compounds 1 and 3 (each within the scatter of the next); then compound 2.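

In this assay, placing 3-fluorophenyl in place of 2-methylprop-1-en-1-yl on this saturated chain carbon gives a 1.1-fold higher number from compound 1 to compound 3 (0.02 log units; within the scatter), so the two compounds cannot be told apart. The earlier pair, compound 1 and compound 2, differs in more than one place, so it could not isolate any single group. This step, by contrast, shows that at this position an aromatic ring of carbon bearing fluorine and an open chain with a double bond read alike on the shared core. Nothing measured here gives a reason for this result.

From the compounds shown here alone, how a plain phenyl, a longer chain or an amine would read at this position remains open. So does whether the fluorine on the ring contributes anything to the value of compound 3.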